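The compounds below may be only part of what the source reports. "The series", "measured", "known", "first", "only" and "open" are said of these compounds alone.

Measured compounds:
compound 1 `Nc1nc(N)c2c(-c3ccsc3)cn([C@@H]3O[C@H](CO)[C@@H](O)[C@H]3O)c2n1` — > 20000 nM
compound 2 `COc1ncnc2c1c(I)cn2[C@@H]1O[C@H](CO)[C@@H](O)[C@H]1O` — 14300 nM
compound 3 `CN(C)c1ncnc2c1c(-c1cc3ccccc3o1)cn2[C@@H]1O[C@H](CO)[C@@H](O)[C@H]1O` — > 20000 nM

Three nucleoside analogues were tested in a functional assay on HeLa S3 cells (Homo sapiens) for antiproliferative activity, read by XTT assay, with a stated time of 72 h; a higher number here means a weaker inhibitor, a lower number a stronger inhibitor. Compound 1 `Nc1nc(N)c2c(-c3ccsc3)cn([C@@H]3O[C@H](CO)[C@@H](O)[C@H]3O)c2n1` gave only a limit of the assay, > 20000 nM. Compound 3 `CN(C)c1ncnc2c1c(-c1cc3ccccc3o1)cn2[C@@H]1O[C@H](CO)[C@@H](O)[C@H]1O` likewise gave only a limit, > 20000 nM. Among the compounds with values here, compound 2 `COc1ncnc2c1c(I)cn2[C@@H]1O[C@H](CO)[C@@H](O)[C@H]1O` is the single compound for which a number was obtained in this assay, 14300 nM, and so it stands alone among the values shown; no pair of measured compounds differs in one place, and no measured step can be drawn from them.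

The next compound, compound 4 `COc1ncnc2c1c(-c1ccoc1)cn2[C@@H]1O[C@H](CO)[C@@H](O)[C@H]1O`, differs from compound 2 in one place: furan-3-yl in place of iodo on an aromatic carbon. Because the limit of > 20000 nM in this assay, at which 2 of the 3 values shown sit, holds two of the three results, an aryl substituent at this position has so far not been accompanied by a measurable number, and compound 4 carries such a substituent. The account therefore expects a step in this assay in the direction of weaker inhibition from compound 2 to compound 4, likely beyond the usual scatter, with a real chance that only a limit is returned. The expected step is a 1.7-fold higher number from compound 2 to compound 4 (0.22 log units; within the scatter). Compound 4 is estimated at 24000 nM, within a range of 7000 nM to 80000 nM.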

Compound 4, half-maximal inhibitory concentration: 1790 nM
For compound 4 the middle estimate is 13-fold (1.13 log units) above the measured one; measured number outside the range, below it.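

In this assay, the change at this aromatic carbon gives the first measured step among the compounds shown, an 8.0-fold lower number from compound 2 to compound 4 (0.90 log units; beyond the scatter), and it runs beyond the scatter towards stronger inhibition. It shows that furan-3-yl at this position, two ring bonds from the ring nitrogen, can accompany a real number and a stronger one than iodo gives on the same core, although a single pair cannot say whether the ring as a whole or its oxygen accounts for the step. Compound 4 is thus an aryl-bearing compound with a measured number, while compound 1 and compound 3, which differ from it in more than one place, each remain at a limit of the assay and not at a number: the limit of > 20000 nM in this assay, at which 2 of the 4 values shown sit.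

The compounds shown leave open whether a phenyl ring, a methyl group or an amine at this carbon would follow furan-3-yl or iodo. They also leave open whether the step holds when the methoxy group on the core gives way to another group, such as an ethyl chain, with furan-3-yl kept in place.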